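A methyl-to-trifluoromethyl swap on compound 2

The compounds below may be only part of what the source reports. "The series", "measured", "known", "first", "only" and "open" are said of these compounds alone.

Measured in a functional assay on HL-60 cells (Homo sapiens) for antiproliferative activity, read by sulforhodamine B assay, with a stated time of 72 h; on this read-out lower numbers stand for stronger inhibition and higher numbers for weaker inhibition:
- Compound 1 `Fc1ccccc1NC(=S)N/N=C/c1ccc2ccccc2n1`: > 100000 nM (a limit of the assay, not a number)
- Compound 2 `Cc1ccc(NC(=S)N/N=C/c2ccc3ccccc3n2)cc1`: 78300 nM
- Compound 3 `S=C(N/N=C/c1ccc2ccccc2n1)Nc1ccccc1Br`: > 100000 nM (a limit of the assay, not a number)

Compound 2 is the only one of the three with an actual number, 78300 nM. Compound 1 and compound 3 both stand at the limit of > 100000 nM in this assay, at which 2 of the 3 values shown sit, so there is little to compare it with.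

Compound 4 `FC(F)(F)c1ccc(NC(=S)N/N=C/c2ccc3ccccc3n2)cc1` has trifluoromethyl in place of methyl on an aromatic carbon, para to a large group, where compound 2 has methyl: trifluoromethyl in place of methyl on an aromatic carbon.

The measured steps offer only weak guidance, since each of them changes the group on the amide-type nitrogen as a whole. They are an at least 1.2-fold lower number from compound 1 to compound 2 (0.10 log units; that floor lies within the scatter) and an at least 1.2-fold higher number from compound 2 to compound 3 (0.10 log units; that floor lies within the scatter), while the third is a step that the two limits leave unreadable from compound 1 to compound 3. None of them replaces methyl with trifluoromethyl, so they set no size for this change. Going by these compounds, no step beyond the scatter is therefore expected in this assay, and the direction stays open.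

The estimate amounts to an expected 1.3-fold lower number from compound 2 to compound 4 (0.12 log units; within the scatter). For compound 4 the expected value is 60000 nM, with an estimated range from 20000 nM to 100000 nM.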

Compound 4, half-maximal inhibitory concentration: 34900 nM
Compound 4: the middle estimate sits 1.7-fold (0.24 log units) above what was measured; the range from low to high includes it.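

In this assay, replacing methyl with trifluoromethyl on the aromatic carbon para to a large group gives a 2.2-fold lower number from compound 2 to compound 4 (0.35 log units; beyond the scatter), and this is the first step shown that lies clearly beyond the scatter. It shows that the number can move in response to a small change at this one position, although compound 4 still needs a high concentration, at 34900 nM. The earlier steps could not show this, since each replaced the whole group on the amide-type nitrogen and each had a limit of the assay at one end or both: the limit of > 100000 nM in this assay, at which 2 of the 4 values shown sit.

One pair of compounds cannot say whether the lower number belongs to trifluoromethyl alone or would also appear with other groups on the same carbon, such as chloro, methoxy, an amine or a carboxylic acid. It also leaves open whether trifluoromethyl on a different carbon of the same ring would give a step of similar size, and the numbers shown do not explain why this swap lowers the value.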